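Benzimidazolone methylation at the piperidine carbon

A few compounds are considered here, and "the series" means these few. Any claim that something is new, unique, unknown or untested is made for them only; others in the source may bear on it.

Compound 1 `CC(=O)N1CCc2c(c(-c3ccc(Cl)c(C)c3)nn2CC(O)CN2CCC(n3c(O)nc4cc(C)ccc43)CC2)C1` gives 100 nM in an assay on isolated protein for inhibition of cathepsin S (Homo sapiens) (on this read-out lower numbers stand for stronger inhibition and higher numbers for weaker inhibition), compound 2 `Cc1cc(-c2nn(CC(O)CN3CCC(n4c(O)nc5ccc(Cl)cc54)CC3)c3c2CN(S(C)(=O)=O)CC3)ccc1Cl` gives 50 nM and compound 3 `CS(=O)(=O)N1CCc2c(c(-c3ccc(C(F)(F)F)cc3)nn2CC(O)CN2CCC(n3c(O)nc4ccc(Cl)cc43)CC2)C1` gives 60 nM. Compound 3 holds the second highest of the three numbers; compound 2 is nearest and compound 1 furthest, both within the scatter. Within the data shown here, the only comparable step, a 1.2-fold higher number from compound 2 to compound 3 (0.08 log units; within the scatter), concerns the aryl group on the shared core and not the saturated-ring substituent. Compound 4 `Cn1c(=O)n(C2CCN(CC(O)Cn3nc(-c4ccc(C(F)(F)F)cc4)c4c3CCN(S(C)(=O)=O)C4)CC2)c2cc(Cl)ccc21` differs from compound 3 by a group of 12 heavy atoms (8 carbon, 2 nitrogen, 1 oxygen, 1 chlorine; one five-membered aromatic ring with 2 hetero atoms, one six-membered aromatic ring of carbon only) in place of a group of 11 heavy atoms (7 carbon, 2 nitrogen, 1 oxygen, 1 chlorine; one five-membered aromatic ring with 2 hetero atoms, one six-membered aromatic ring of carbon only), on a saturated ring carbon. Among the measured compounds shown here, no measured step touches this position, so the change has no established direction, and only a step within or near the scatter is expected, a 1.7-fold higher number from compound 3 to compound 4 (0.22 log units; within the scatter). Compound 4 is therefore estimated at 100 nM, with a range from 30 nM to 400 nM.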

Compound 4, half-maximal inhibitory concentration: 80 nM
Compound 4: the middle estimate sits 1.3-fold (0.10 log units) above what was measured, within the range that was stated.
By their numbers in this assay, from the lowest: compounds 2, 3, 4 and 1 (each within the scatter of the next).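

In this assay, the change on the saturated ring carbon gives the first step read at this position, a 1.3-fold higher number from compound 3 to compound 4 (0.12 log units; within the scatter), with 6-chloro-2-hydroxy-1H-benzimidazol-1-yl and its 1 hydrogen-bond donor leaving and a group of 12 heavy atoms with 0 hydrogen-bond donors entering. In this pair, with 4-(trifluoromethyl)phenyl on the shared core, inhibition therefore does not depend on that donor. No evidence at hand bears on this result. From the compounds shown here alone, whether the same holds with the 4-chloro-3-methylphenyl group of compound 2 stays open, as does the effect of an amine or a carboxylic acid on that ring carbon.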